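Shortening an alkyl chain: three measured compounds, one awaited

This account rests on a few compounds, and the source may have more. Where it says the series, first, only, none or still open, it means among the compounds named here.

In a functional assay on Hep 3B2 cells (Homo sapiens) for antiproliferative activity, read by MTT assay, with a stated time of 24 h, tested at 3.7 ug/mL (a higher number here means a stronger effect of the compound at the concentration tested, a lower number a weaker effect), three compounds have been measured:
compound 1 `Cc1ccc2nc(C(=O)Nc3c(F)cc(-c4cccc(F)c4)cc3F)c(C)c(O)c2c1` gives 19.2%;
compound 2 `CCc1ccc2nc(C(=O)Nc3c(F)cc(-c4cccc(F)c4)cc3F)c(C)c(O)c2c1` gives 31.2%;
compound 3 `CCOc1ccc2nc(C(=O)Nc3c(F)cc(-c4cccc(F)c4)cc3F)c(C)c(C(=O)O)c2c1` gives 26.5%.

Compound 1 and compound 2 share one core and differ in a single place: hydrogen in place of methyl on a saturated chain carbon bound to an aromatic carbon. That change produced a number 12 percentage points lower from compound 2 to compound 1 (beyond the scatter). Compound 3 carries a different core; the difference between the two cores is not broken down here. Compound 4 `COc1ccc2nc(C(=O)Nc3c(F)cc(-c4cccc(F)c4)cc3F)c(C)c(C(=O)O)c2c1` is derived from compound 3 by hydrogen in place of methyl on a saturated chain carbon bound to an oxygen on an aromatic ring. Among the measured compounds shown here, this is the same kind of change as the one from compound 2 to compound 1, but its place is not the same: in the earlier pair the saturated chain carbon is bound to an aromatic carbon, whereas in compound 4 it is bound to an oxygen on an aromatic ring. Because the earlier pair showed a number 12 percentage points lower from compound 2 to compound 1 (beyond the scatter), a drop of similar direction is expected here. For the measured compounds named here, only one such step is known, and it sits on a different core and at a different place, so the expected step is taken as smaller and less certain. The step expected in this assay is a number 7.5 percentage points lower from compound 3 to compound 4 (within the scatter). Compound 4 is estimated at 19%, with a lower end of 8% and an upper end of 32%.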

Compound 4, a percentage reported as inhibition, at one concentration (the size of the read-out at that concentration, not a potency): 1.62%
The estimate for compound 4 lay 17.4 percentage points above the measured number, and the stated range ends above it.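

In this assay, shortening ethoxy to methoxy gave a number 24.9 percentage points lower from compound 3 to compound 4 (beyond the scatter), the same direction as the step from ethyl to methyl on the other core. Set side by side, the two steps agree in direction, and the gap between them does not separate them in size: the same change on two cores in this assay, a number 12 percentage points lower (beyond the scatter) from compound 2 to compound 1 and a number 24.9 percentage points lower (beyond the scatter) from compound 3 to compound 4, 12.9 percentage points apart, within the scatter of two such steps. This shows that removing the methyl lowered the number on both cores, but two steps at two different places do not establish a general rule for the series, and they do not show whether the core or the place of the change has any bearing on the size of the step.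

The compounds shown leave open whether a longer chain, such as propyl or propoxy, would continue this direction or level off. They also leave open whether an amine carrying the same methyl or ethyl would respond to the shortening as the two chains shown here did.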